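Adding One Methyl to Compound 3

The source may report more compounds than this note shows. Statements on the series, on what has been measured and on what is new or still open speak of the compounds shown alone.

In an ADME assay on microsomes from liver (Homo sapiens) for pharmacokinetics, read by LC-MS, with a stated time of 60 min, tested at 1 uM (on this read-out lower numbers stand for slow clearance and higher numbers for fast clearance), compound 1 `C[C@@H]1COC[C@@H](C)N1S(=O)(=O)c1ccc(NC(=O)NCc2cccnc2)cc1` gives 17 mL/min/kg, compound 2 `O=C(NCc1cccnc1)Nc1ccc(S(=O)(=O)N2C3CCC2COC3)cc1` gives 8 mL/min/kg and compound 3 `O=C(NCc1cccnc1)Nc1ccc(S(=O)(=O)N2CCCNCC2)cc1` gives 6 mL/min/kg. Compound 3 sits level with compound 2: the step of a 1.3-fold lower number from compound 2 to compound 3 (0.12 log units; within the scatter) stays within the scatter, while the modest step of a 2.8-fold lower number from compound 1 to compound 3 (0.45 log units; beyond the scatter) lies beyond it. Compound 4 `CC1CNCCN(S(=O)(=O)c2ccc(NC(=O)NCc3cccnc3)cc2)C1` carries methyl in place of hydrogen on a saturated ring carbon. Among the measured compounds shown here, no measured step adds a single methyl to this ring. The closest guide is a 2.8-fold lower number from compound 1 to compound 3 (0.45 log units; beyond the scatter), which swapped 3,5-dimethylmorpholin-4-yl for 1,4-diazepan-1-yl. The expected step is small and upward, within the scatter: a 1.3-fold higher number from compound 3 to compound 4 (0.12 log units; within the scatter). For compound 4 the estimated clearance is 8 mL/min/kg, with an expected range of 4 mL/min/kg to 15 mL/min/kg.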

Compound 4, clearance: 8 mL/min/kg
Estimate against measurement, compound 4: no gap at the digits printed, and the stated range covers the measured number.
By their numbers in this assay, from the lowest: compounds 3, 2 and 4 (each within the scatter of the next); then compound 1.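

Methyl on this saturated ring carbon, two ring bonds from the ring nitrogen, is the first change here made to the seven-membered ring alone, and in this assay the result is a 1.3-fold higher number from compound 3 to compound 4 (0.12 log units; within the scatter), so the two compounds stand level. The added methyl also leaves the picture against the other ring groups as it was, with no change at the digits printed from compound 2 to compound 4 (within the scatter) and a 2.1-fold lower number from compound 1 to compound 4 (0.33 log units; beyond the scatter). Nothing measured here explains these numbers. As far as these compounds go, whether a larger group on this carbon, such as ethyl or hydroxymethyl, would also stay level remains open. So does the effect of methyl on the other ring carbons or on the ring nitrogen that carries hydrogen.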